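Bicyclic amines on the shared core: compound 4 expectation

The source may hold more compounds than are shown below. What is called first, only, known or untested is meant among the compounds shown, and "the series" means these compounds.

Measured compounds:
compound 1 `Cn1c(=O)c(S(=O)(=O)c2ccc(F)cc2F)cc2cnc(Nc3ccc4occc4c3)nc21` gives 15000 nM
compound 2 `Cc1cc2cc(Nc3ncc4cc(S(=O)(=O)c5ccc(F)cc5F)c(=O)n(C)c4n3)ccc2[nH]1` gives 750 nM
compound 3 `Cn1c(=O)c(S(=O)(=O)c2ccc(F)cc2F)cc2cnc(Nc3ccncn3)nc21` gives 50000 nM

In a functional assay on DU-145 cells (Homo sapiens) for inhibition, read by trypan blue exclusion, with a stated time of 72 h (on this read-out higher numbers stand for weaker inhibition and lower numbers for stronger inhibition), compound 3 stands highest of the three, weakest by a wide margin. Compound 4 `Cn1c(=O)c(S(=O)(=O)c2ccc(F)cc2F)cc2cnc(Nc3cnc4[nH]ccc4c3)nc21` is made from it by the change (a group of 9 heavy atoms (7 carbon, 2 nitrogen; one five-membered aromatic ring with 1 hetero atom, one six-membered aromatic ring with 1 hetero atom) in place of a group of 6 heavy atoms (4 carbon, 2 nitrogen; one six-membered aromatic ring with 2 hetero atoms), on a nitrogen on an aromatic ring). The bearing steps are a 67-fold higher number from compound 2 to compound 3 (1.82 log units; beyond the scatter) and a 3.3-fold higher number from compound 1 to compound 3 (0.52 log units; beyond the scatter): exchanging pyrimidin-4-yl for either bicyclic group lowers the number, and the indole bearing a hydrogen-bond donor does so most. Compound 4 also brings a fused five-membered ring with one hetero atom and one hydrogen-bond donor, so a large downward step is expected, a 25-fold lower number from compound 3 to compound 4 (1.40 log units; beyond the scatter). Compound 4 is therefore estimated at 2000 nM, with a range from 500 nM to 12000 nM.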

Compound 4, half-maximal inhibitory concentration: 750 nM
Compound 4: the middle estimate sits 2.7-fold (0.43 log units) above what was measured, within the range that was stated.
By their numbers in this assay, from the lowest: compounds 2 and 4 (each within the scatter of the next); then compound 1; then compound 3.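

In this assay, a bicyclic group with a nitrogen in its six-membered ring and no methyl group reads the same as the 2-methyl-1H-indol-5-yl group (as no change at the digits printed from compound 2 to compound 4 (within the scatter)). Both donor-bearing bicyclic groups therefore stand apart from the oxygen-containing one (with a 20-fold lower number from compound 1 to compound 4 (1.30 log units; beyond the scatter)) and from pyrimidin-4-yl (with a 67-fold lower number from compound 3 to compound 4 (1.82 log units; beyond the scatter)). No measurement at hand gives a cause for these steps. From the compounds shown here alone, whether the hydrogen-bond donor itself carries the steps stays open, and an indole with a methyl group on its ring nitrogen would test this. Going by these compounds, how an amine or a carboxylic acid on the bicyclic group would read is also open.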